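The source may report more compounds than this note shows. Statements on the series, on what has been measured and on what is new or still open speak of the compounds shown alone.

Measured compounds:

- Compound 1 `Cn1c(-c2ccc(NC(=O)CCl)cc2)nc(-c2ccccc2)c1-c1ccccc1`: in a functional assay on MCF7 cells (Homo sapiens) for cytotoxicity, read by MTT assay, with a stated time of 24 h, tested at 80 ug/mL (a lower number here means a weaker effect, a higher number a stronger effect of the compound at the concentration tested), compound 1 gives 70%
- Compound 2 `Cn1c(-c2ccc(NC(=O)CSc3nc4ccccc4o3)cc2)nc(-c2ccccc2)c1-c1ccccc1`: in this assay compound 2 gives 76.3%
- Compound 3 `CN1CCN(CC(=O)Nc2ccc(-c3nc(-c4ccccc4)c(-c4ccccc4)n3C)cc2)CC1`: in this assay compound 3 gives 50.3%

Compound 2 has the largest number of the three, but the step of a number 6.3 percentage points higher from compound 1 to compound 2 (within the scatter) lies within the scatter, so compound 1 and compound 2 cannot be told apart on these data. The step of a number 26 percentage points lower from compound 2 to compound 3 (beyond the scatter) lies beyond the scatter.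

Compound 4 `CCN1CCN(CC(=O)Nc2ccc(-c3nc(-c4ccccc4)c(-c4ccccc4)n3C)cc2)CC1` is not yet measured. Compared with compound 2, the change is 4-ethylpiperazin-1-yl in place of (1,3-benzoxazol-2-yl)sulfanyl on a saturated chain carbon bound to a carbonyl carbon.

Among the measured compounds shown here, two measured steps bear on this. The step of a number 26 percentage points lower from compound 2 to compound 3 (beyond the scatter) and the step of a number 19.7 percentage points lower from compound 1 to compound 3 (beyond the scatter) both end at compound 3, whose group differs from the group entering in compound 4 only in the name of the piperazine substituent. Because of a number 26 percentage points lower from compound 2 to compound 3 (beyond the scatter) a step downward of similar size is expected, estimated as a number 26.3 percentage points lower from compound 2 to compound 4 (beyond the scatter). Compound 4 is therefore estimated at 50% in this assay, with a range from 35% to 65%.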

Compound 4, a percentage reported as activity, at one concentration (the size of the read-out at that concentration, not a potency): 46.3%
Estimate against measurement, compound 4: 3.7 percentage points above; low and high end bracket the measured number.
By their numbers in this assay, from the lowest: compounds 4 and 3 (each within the scatter of the next); then compounds 1 and 2 (each within the scatter of the next).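

Extending the piperazine substituent from methyl to ethyl, a change further out on the group, leaves no readable difference in this assay: the step of a number 4 percentage points lower from compound 3 to compound 4 (within the scatter) means these two compounds cannot be told apart. The lower reading is therefore not confined to the 4-methylpiperazin-1-yl group, as 4-ethylpiperazin-1-yl on the saturated chain carbon bound to a carbonyl carbon gives both a number 30 percentage points lower from compound 2 to compound 4 (beyond the scatter) and a number 23.7 percentage points lower from compound 1 to compound 4 (beyond the scatter), each a step against a group without a piperazine ring. Nothing measured here explains why either piperazine reads lower than chloro or (1,3-benzoxazol-2-yl)sulfanyl.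

On these data alone, it remains open whether a piperazine carrying a longer chain, such as propyl or benzyl, would read the same. A morpholine or a piperidine at this place could show whether the second ring nitrogen of the piperazine has any part in the lower numbers.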